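The source may report more compounds than this note shows. Statements on the series, on what has been measured and on what is new or still open speak of the compounds shown alone.

Among the measured compounds shown here, in a functional assay on BXPC-3 cells (Homo sapiens) for inhibition, read by MTT assay, with a stated time of 7 days (on this read-out higher numbers stand for weaker inhibition and lower numbers for stronger inhibition), compound 1 (`CCCN(CCC)S(=O)(=O)c1ccc(S(=O)(=O)N2CCC[C@@H](C(=O)OCC)C2)cc1`) gives 2500 nM as the higher of the two numbers so far, while compound 2 (`CCN(CC)S(=O)(=O)c1ccc(S(=O)(=O)N2CCC[C@@H](C(=O)NC3CCN(C(=O)OC(C)(C)C)CC3)C2)cc1`) gives 300 nM and sits lower by more than the usual scatter. Compound 3 (`CCOC(=O)[C@@H]1CCCN(S(=O)(=O)c2ccc(S(=O)(=O)N(CC)C(C)C)cc2)C1`) carries ethyl(isopropyl)amino in place of dipropylamino on a sulfonyl sulfur and otherwise matches compound 1. For the measured compounds named here, no measured pair shows this swap, so in this assay no step beyond the scatter is expected, and the estimated step (a 1.1-fold lower number from compound 1 to compound 3 (0.04 log units; within the scatter)) stays small. For compound 3 the expected value is 2300 nM with an estimated range from 900 nM to 6000 nM around it.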

Compound 3, half-maximal inhibitory concentration: 1600 nM
The estimate for compound 3 lay 1.4-fold (0.16 log units) above the measured number, within the range that was stated.
By their numbers in this assay, from the lowest: compound 2; then compounds 3 and 1 (each within the scatter of the next).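

In this assay, ethyl(isopropyl)amino in place of dipropylamino on a sulfonyl sulfur gives a 1.6-fold lower number from compound 1 to compound 3 (0.19 log units; within the scatter), so this swap stays within the usual scatter. Among the compounds shown here, this is the first step that can be read at this position, since compound 1 and compound 2 differ in more than one place. Nothing measured here speaks to the reason for this result. On these data alone, whether dibutylamino, with its longer chains, on the same sulfonyl sulfur would shift the number beyond the scatter remains open. So does the effect of a carboxylic acid in place of the ethyl ester of compound 1.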